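Dropping one methoxy group: expected effect on cell toxicity

A few compounds are considered here, and "the series" means these few. Any claim that something is new, unique, unknown or untested is made for them only; others in the source may bear on it.

Within the data shown here, compound 1 `COc1cc(OC)c(OC)cc1/C=C/C(=O)c1c(O)cc(C)oc1=O` is the only member of the set with a definite number: in an ADME assay on HEK293 cells (Homo sapiens) for cytotoxicity, read by MTT assay (a higher number here means a weaker inhibitor, a lower number a stronger inhibitor), compound 1 gives 100000 nM. Compound 2 `Cc1cc(O)c(C(=O)/C=C/c2cccc(O)c2)c(=O)o1` reaches only a limit in this assay, at > 100000 nM. Compound 3 `Cc1ccc(/C=C/C(=O)c2c(O)cc(C)oc2=O)cc1` likewise stops at a limit, > 100000 nM. Among the measured compounds shown here, compound 1 thus stands at the one real value, while the other two rest at the limit of > 100000 nM in this assay, at which 2 of the 3 values shown sit.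

Compound 4 `COc1ccc(OC)c(/C=C/C(=O)c2c(O)cc(C)oc2=O)c1` differs from compound 1 by hydrogen in place of methoxy on an aromatic carbon. For the measured compounds named here, no step between measured compounds exists to guide the direction, and all three values sit close together. The expected no change at the digits printed from compound 1 to compound 4 (within the scatter) is none beyond the scatter. Compound 4 is estimated at 100000 nM, within 50000 nM to 200000 nM, and may well be reported only as a limit.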

Compound 4, half-maximal inhibitory concentration: 100000 nM
Beside the measured number, compound 4's estimate shows no gap at the digits printed, within the range that was stated.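

In this assay, among these compounds, this pair gives the first step that can be read between compounds differing in one place: no change at the digits printed from compound 1 to compound 4 (within the scatter). On this aromatic carbon, para to a large group, methoxy and hydrogen therefore cannot be told apart beyond the scatter. The step is read close to the point where values stop being numbers: the limit of > 100000 nM in this assay, at which 2 of the 4 values shown sit.

The compounds shown leave open whether an amine or a carboxylic acid on this carbon would give a clearly lower number. They also leave open whether methoxy and hydrogen would still read alike on a core giving lower numbers in this assay.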